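The source may report more compounds than this note shows. Statements on the series, on what has been measured and on what is new or still open speak of the compounds shown alone.

Of the compounds shown here, three sharing one core have been measured in an assay on membranes from frontal cortex for displacement of a labelled ligand from Adrenergic receptor alpha-1 (Rattus norvegicus), read by scintillation counting, with a stated time of 45 min; a higher number here means a weaker inhibitor, a lower number a stronger inhibitor. Compound 1 `CCC1(CCCCN2CCN(c3ccc(Cl)cc3)CC2)C(=O)Nc2cc(F)ccc21` gives 215 nM. Compound 2 `O=C1Nc2ccccc2C1CCCCN1CCN(c2cccc(Cl)c2)CC1` gives 26 nM. Compound 3 `O=C1Nc2cc(F)ccc2C1CCCCN1CCN(c2cccc(Cl)c2)CC1` gives 12.5 nM, the lowest of the three numbers; compound 2 is its nearest neighbour and compound 1 its furthest. Within the data shown here, the only single-point step among the measured compounds, fluoro in place of hydrogen on an aromatic carbon, is a 2.1-fold lower number from compound 2 to compound 3 (0.32 log units; beyond the scatter). Compound 1 differs from compound 3 in two places at once, an ethyl group on the shared core and the chlorophenyl group itself, so its much higher number cannot be assigned to either change alone.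

Compound 4 `O=C1Nc2cc(F)ccc2C1CCCCN1CCN(c2ccc(Cl)cc2)CC1` has the same atoms as compound 3, joined differently: 4-chlorophenyl in place of 3-chlorophenyl on an amine nitrogen in a ring. Among the measured compounds shown here, no measured pair isolates this change. The step from compound 2 to compound 3 concerns a different part of the molecule and does not bear on it. The gap between compound 1 and compound 3 points loosely toward a weaker inhibitor when the chlorine sits on the 4-chlorophenyl, but that gap is confounded. A modest rise in the number is therefore expected, a 2.0-fold higher number from compound 3 to compound 4 (0.30 log units; within the scatter), with wide uncertainty. Compound 4 is estimated at 25 nM, expected to fall between 8 nM and 80 nM.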

Compound 4, inhibition constant: 55 nM
The estimate for compound 4 lay 2.2-fold (0.34 log units) below the measured number, within the range that was stated.
By their numbers in this assay, from the lowest: compound 3; then compound 2; then compound 4; then compound 1.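

Among these compounds, compound 3 and compound 4 have the same atoms, so this pair gives the first clean reading of where the chlorine sits: in this assay, 4-chlorophenyl in place of 3-chlorophenyl on the ring amine nitrogen gives a 4.4-fold higher number from compound 3 to compound 4 (0.64 log units; beyond the scatter), a step beyond the usual scatter towards a weaker inhibitor. Compound 4 also separates the two changes that were tangled together in compound 1, since hydrogen in place of ethyl on a saturated ring carbon, with the 4-chlorophenyl kept, gives a 3.9-fold lower number from compound 1 to compound 4 (0.59 log units; beyond the scatter), again beyond the scatter, so the ethyl-bearing compound 1 is the weaker inhibitor of this pair and the chlorophenyl change is not the only one that counts. No evidence on the cause of either step is available here.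

As far as these compounds go, it remains open whether a phenyl group without chlorine, or a bromophenyl or methoxyphenyl group, would give a number nearer to that of compound 3 or of compound 4, and whether a methyl group in place of the ethyl would fall short of the ethyl step. From the compounds shown here alone, it is also open whether the fluoro step seen with 3-chlorophenyl would carry over to 4-chlorophenyl.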